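Phenoxy to benzyloxy: from compound 2 to compound 4

The compounds below may be only part of what the source reports. "The series", "measured", "known", "first", "only" and "open" are said of these compounds alone.

Measured so far in an ADME assay on BHK-21 cells (Mesocricetus auratus) for cytotoxicity, read by MTT assay, with a stated time of 72 h; a higher number here means that more compound is tolerated, a lower number that less compound is tolerated:
- compound 1 `Cc1cccc(C2CC(c3ccc(Oc4ccccc4)cc3)=NN2c2ccc(S(N)(=O)=O)cc2)c1`: 8000 nM
- compound 2 `NS(=O)(=O)c1ccc(N2N=C(c3ccc(Oc4ccccc4)cc3)CC2c2ccccc2F)cc1`: 32000 nM
- compound 3 `NS(=O)(=O)c1ccc(N2N=C(c3ccc(Oc4ccccc4)cc3)CC2c2ccc(F)cc2)cc1`: 8000 nM

Compound 2 gives the highest number of the three in this assay; the step of a 4.0-fold higher number from compound 1 to compound 2 (0.60 log units; beyond the scatter) and the step of a 4.0-fold lower number from compound 2 to compound 3 (0.60 log units; beyond the scatter) both set it apart, while the step of no change at the digits printed from compound 1 to compound 3 (within the scatter) leaves compound 1 and compound 3 indistinguishable. All three measured steps vary only the aryl group on the saturated ring carbon of the shared core.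

Compound 4 `NS(=O)(=O)c1ccc(N2N=C(c3ccc(OCc4ccccc4)cc3)CC2c2ccccc2F)cc1` differs from compound 2 elsewhere: benzyl in place of phenyl on an oxygen on an aromatic ring. The aryl group on the saturated ring carbon is the 2-fluorophenyl of compound 2, unchanged.

Going by the values given here, no measured step touches the oxygen on the aromatic ring, so none of the three steps bears directly on this change. There is therefore no basis in the measured compounds for expecting a step in either direction beyond the scatter. The working expectation for compound 4 in this assay is a step of about no change at the digits printed from compound 2 to compound 4 (within the scatter), that is, a number close to that of compound 2. On these data alone, compound 4 is thus estimated at 32000 nM, with a range from 12000 nM to 80000 nM, kept wide because the change is untested.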

Compound 4, half-maximal cytotoxic concentration: 90000 nM
For compound 4 the middle estimate is 2.8-fold (0.45 log units) below the measured one; measured number outside the range, above it.
By their numbers in this assay, from the lowest: compounds 1 and 3 (each within the scatter of the next); then compound 2; then compound 4.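

Going by these compounds alone, the oxygen on an aromatic ring is the first place outside the aryl group on the saturated ring carbon to be varied in this assay, and the number responds there too: benzyl in place of phenyl gives a 2.8-fold higher number from compound 2 to compound 4 (0.45 log units; beyond the scatter). The series therefore has two places where a single change moves the number beyond the scatter, and this step runs in the same direction as the change to 2-fluorophenyl (a 4.0-fold higher number from compound 1 to compound 2 (0.60 log units; beyond the scatter)), toward more compound being tolerated. The measured compounds offer no explanation for the rise from phenoxy to benzyloxy, and nothing here bears on its cause.

The phenoxy to benzyloxy change is shown only with the 2-fluorophenyl group in place, so it remains open whether the same step would appear with the 4-fluorophenyl or 3-methylphenyl group on the saturated ring carbon. On these data alone, it is also open whether the number would keep rising, level off or fall with a phenethyl group or a plain methyl group on that oxygen, which would show whether the rise belongs to benzyl specifically.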